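Methyl to Fluoro on Two Related Cores

The compounds below may be only part of what the source reports. "The series", "measured", "known", "first", "only" and "open" are said of these compounds alone.

In a functional assay on HCT-116 cells (Homo sapiens) for antiproliferative activity, read by MTT assay, with a stated time of 48 h (on this read-out higher numbers stand for weaker inhibition and lower numbers for stronger inhibition), compound 1 `Cc1cnc(Nc2ccc(S(C)(=O)=O)cc2)nc1Nc1nc2ccc(Cl)cc2s1` gives 2500 nM. Compound 2 `CS(=O)(=O)c1ccc(Nc2ncc(F)c(Nc3nc4ccc(Cl)cc4s3)n2)cc1` carries the change (fluoro in place of methyl on an aromatic carbon), and in this assay compound 2 gives 20700 nM, so the step is an 8.3-fold higher number from compound 1 to compound 2 (0.92 log units; beyond the scatter). Compound 3 `COc1ccc2nc(Nc3nc(Nc4ccc(S(N)(=O)=O)cc4)ncc3C)sc2c1` rests on a different core, and how that core differs from the core of compound 1 is not broken down here; in this assay compound 3 gives 7860 nM. Compound 4 `COc1ccc2nc(Nc3nc(Nc4ccc(S(N)(=O)=O)cc4)ncc3F)sc2c1` is not yet measured. It differs from compound 3 by fluoro in place of methyl on an aromatic carbon, the same change as from compound 1 to compound 2, at the same place. That earlier change gave an 8.3-fold higher number from compound 1 to compound 2 (0.92 log units; beyond the scatter), so a weakening is expected, and for compound 4 the expected step is a 5.1-fold higher number from compound 3 to compound 4 (0.71 log units; beyond the scatter). Compound 4 is estimated at 40000 nM, with a range from 12000 nM to 130000 nM.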

Compound 4, half-maximal inhibitory concentration: 11500 nM
For compound 4 the middle estimate is 3.5-fold (0.54 log units) above the measured one; the measured number lies below the stated range.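

In this assay, fluoro in place of methyl gives a 1.5-fold higher number from compound 3 to compound 4 (0.17 log units; within the scatter), so on this core compound 3 and compound 4 cannot be told apart. The large step seen on the core of compound 1 therefore did not carry over in size, and the gap between the two steps is real rather than scatter: the same change on two cores in this assay, an 8.3-fold higher number (0.92 log units; beyond the scatter) from compound 1 to compound 2 and a 1.5-fold higher number (0.17 log units; within the scatter) from compound 3 to compound 4, 5.7-fold (0.75 log units) apart, beyond the scatter of two such steps. Two pairs do not show which difference between the cores sets the size of the step, nor how the change would behave on a further core.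

The compounds shown leave open how other groups at this place, such as an ethyl group, a nitrile or an amine, would compare with methyl and fluoro on either core.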